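Pyrrolidin-1-yl in place of cyclopropylamino on the shared core

This account rests on a few compounds, and the source may have more. Where it says the series, first, only, none or still open, it means among the compounds named here.

In a functional assay on HepG2 cells (Homo sapiens) for inhibition, with a stated time of 72 h (on this read-out higher numbers stand for weaker inhibition and lower numbers for stronger inhibition), compound 3 (`O=C(Nc1ccccc1)Nc1nc(NC2CC2)cc(Sc2c[nH]c3ccccc23)n1`) gives 14300 nM and lies within the scatter of the other two measured compounds: compound 1 (`Cc1cc(Cl)ccc1NC(=O)Nc1nc(Sc2c[nH]c3ccccc23)cc(N2CCN(Cc3ccccc3)CC2)n1`) gives 11700 nM and compound 2 (`COc1ccc(NC(=O)Nc2nc(Sc3c[nH]c4ccccc34)cc(N3CCN(c4ccccn4)CC3)n2)cc1`) gives 11400 nM on the same scale. Compound 4 (`O=C(Nc1ccccc1)Nc1nc(Sc2c[nH]c3ccccc23)cc(N2CCCC2)n1`) carries pyrrolidin-1-yl in place of cyclopropylamino on an aromatic carbon. Going by the values given here, no measured pair in this assay isolates this change. Compound 1 and compound 2 also lack the cyclopropylamino group, yet both stay within the scatter of compound 3 (14300 nM), so no step beyond the scatter is expected in either direction. An estimated 1.1-fold lower number from compound 3 to compound 4 (0.04 log units; within the scatter) is expected on this basis. For compound 4 the expected value is 13000 nM within an estimated range (6500 nM to 26000 nM).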

Compound 4, half-maximal inhibitory concentration: 11400 nM
For compound 4 the middle estimate is 1.1-fold (0.06 log units) above the measured one; the measured number falls inside the stated range.
By their numbers in this assay, from the lowest: compounds 2, 4, 1 and 3 (each within the scatter of the next).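

Going by these compounds alone, this is the first pair to isolate this position: in this assay, replacing cyclopropylamino with pyrrolidin-1-yl on the aromatic carbon gives a step within the scatter (a 1.3-fold lower number from compound 3 to compound 4 (0.10 log units; within the scatter)). The swap removes the one hydrogen-bond donor of the leaving group and changes the ring size, yet the read-out shows no resolved difference. Nothing available bears on a cause for this.

Still open, from the compounds shown here alone, is whether a step beyond the scatter can arise at this position, for instance with morpholin-4-yl or a primary amine.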